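This account rests on a few compounds, and the source may have more. Where it says the series, first, only, none or still open, it means among the compounds named here.

- compound 1 `COc1ccc(C(=O)/C=C/c2ccc(F)cc2)c2c1C=CC(C)(C)O2`: > 10000 nM
- compound 2 `COc1ccc(C(=O)/C=C/c2ccc(Cl)c(Cl)c2)c2c1C=CC(C)(C)O2`: 9030 nM

Both compounds share one core and differ only in the ring at the end of the chain. Compound 1 reaches only a limit in a functional assay on K562 cells (Homo sapiens) for antiproliferative activity, read by MTT assay, with a stated time of 24 h (on this read-out higher numbers stand for weaker inhibition and lower numbers for stronger inhibition), > 10000 nM, and this is not a true number. Among the compounds with values here, compound 2, at 9030 nM, therefore holds the only actual number so far, which leaves nothing firm to rank it against.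

The next compound to be tested is compound 3 `COc1ccc(C(=O)/C=C/c2ccc(O)cc2)c2c1C=CC(C)(C)O2`. It carries 4-hydroxyphenyl in place of 3,4-dichlorophenyl on a double-bonded chain carbon bound to a double-bonded chain carbon.

Within the data shown here, the only measured guide is the step of an at least 1.1-fold lower number from compound 1 to compound 2 (0.04 log units; that floor lies within the scatter), which also changes this ring. Its floor lies within the scatter, so it shows no clear change. It is a weak guide, since it involves different groups and ends at a limit. No step beyond the scatter is therefore expected in this assay, in either direction. Another limit may well appear, given (the limit of > 10000 nM in this assay, at which 1 of the 2 values shown sits).

The estimated step is a 1.0-fold lower number from compound 2 to compound 3 (0.00 log units; within the scatter). For compound 3 the expected value is 9000 nM, with an estimated range of 3500 nM to 20000 nM.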

Compound 3, half-maximal inhibitory concentration: > 10000 nM
Compound 3: no number, only a limit; the forecaster's own chance of this, stated with the estimate: 45%; middle value at least 1.1-fold (0.04 log units) from the limit.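

The step to 4-hydroxyphenyl, which brings a hydrogen-bond donor and a hydrogen-bond acceptor that 3,4-dichlorophenyl lacks, gives an at least 1.1-fold higher number from compound 2 to compound 3 (0.04 log units; that floor lies within the scatter), so no clear change can be claimed at this place on the chain, and what the change adds is that this new kind of ring also yields no firm gain. The steps that join compound 1 to compound 3 cannot be read, since both values are limits, so fluoro and hydroxy cannot be ranked against each other. The series in this assay now gathers mostly at one ceiling, and that ceiling hides any differences beyond it: the limit of > 10000 nM in this assay, at which 2 of the 3 values shown sit.

From the compounds shown here alone, it remains open whether any group on this ring can bring the number clearly under that of compound 2, which stands at 9030 nM. A dimethylamino group, a carboxylic acid or a pyridine ring in place of the phenyl ring would test whether this position can respond at all, or whether the shared core sets the result in these cells.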